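The compounds below may be only part of what the source reports. "The series", "measured", "known", "first", "only" and "open" are said of these compounds alone.

Of the compounds shown here, three have been measured in an assay on isolated protein for displacement of a labelled ligand from metabotropic glutamate receptor 5 (Homo sapiens), with a stated time of 60 min, tested at 1 uM; a higher number here means more inhibition at the concentration tested (going by the name of the read-out), a lower number less inhibition. Compound 3 `CC1CCN(c2c(S(=O)(=O)c3ccccc3)cnc3cc(Cl)ccc23)CC1` gives 93%. Compound 2 `CC1CCN(c2c(S(=O)(=O)c3ccccc3)cnc3ccccc23)CC1` gives 89.2%, a number that lies within the scatter of that of compound 3. Compound 1 `COc1ccc(S(=O)(=O)c2cnc3ccc(C)cc3c2N2CCC(C)CC2)cc1` gives 62%, a number beyond the scatter below the other two; compound 1 differs from compound 3 in more than one place, so only the two values themselves can be set side by side. One single-point step is known: a number 3.8 percentage points higher from compound 2 to compound 3 (within the scatter), a change that stayed within the scatter. Compound 4 `CC1CCN(c2c(S(=O)(=O)c3ccc(Cl)cc3)cnc3cc(Cl)ccc23)CC1` differs from compound 3 by chloro in place of hydrogen on an aromatic carbon. Among the compounds with values here, the only measured step that bears on this change, the one from compound 2 to compound 3, also introduced a chloro substituent and moved the number by less than the scatter. Compound 4 is therefore expected to show no step beyond the scatter, a number 3 percentage points lower from compound 3 to compound 4 (within the scatter). The estimate for compound 4 is 90%, with a range from 78% to 97%.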

Compound 4, a percentage reported as inhibition, at one concentration (the size of the read-out at that concentration, not a potency): 91%
Estimate against measurement, compound 4: 1 percentage points below; measured number inside the range.
By their numbers in this assay, from the lowest: compound 1; then compounds 2, 4 and 3 (each within the scatter of the next).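

The earlier compounds shown here carried a chloro only on the shared core, whereas compound 4 places one on the phenyl ring, on an aromatic carbon para to a large group. In this assay, the change from phenyl to 4-chlorophenyl gives a number 2 percentage points lower from compound 3 to compound 4 (within the scatter), so this position accepts a chloro with no change beyond the scatter, even with the chloro of compound 3 already on the core. No measurement shown here accounts for this result.

As far as these compounds go, it remains open whether an amine or a carboxylic acid at this position would move the number beyond the scatter. Compound 1, at 62%, differs from these compounds in more than one place, so the source of its lower number also stays unresolved.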